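This account rests on a few compounds, and the source may have more. Where it says the series, first, only, none or still open, it means among the compounds named here.

Measured in a functional assay on A549 cells (Homo sapiens) for antiproliferative activity, read by sulforhodamine B assay, with a stated time of 72 h; a lower number here means a stronger inhibitor, a higher number a weaker inhibitor:

- Compound 1 `CCOC(=O)c1cn2cc(-c3cnc(OC)c(NS(=O)(=O)c4ccc(F)cc4)c3)ccc2n1`: > 20000 nM, which is a limit of the assay
- Compound 2 `CCOC(=O)c1cnc2ccc(-c3cnc(OC)c(NS(C)(=O)=O)c3)cn12`: 230 nM
- Compound 3 `COc1ncc(-c2ccc3ncc(C(=O)N4CCC(OC(=O)c5ccccc5)CC4)n3c2)cc1NS(=O)(=O)c1ccc(F)cc1F`: 1620 nM

Among the measured compounds shown here, of the two exact numbers, the one for compound 2 is the lower, and its gap to compound 3 lies beyond the scatter. Compound 4 `CCCCS(=O)(=O)Nc1cc(-c2ccc3ncc(C(=O)OCC)n3c2)cnc1OC` has not yet been measured. It differs from compound 2 as follows: propyl in place of hydrogen on a saturated chain carbon bound to a sulfonyl sulfur. Propyl takes the place of hydrogen on a saturated chain carbon bound to a sulfonyl sulfur, so methylsulfonyl becomes butylsulfonyl. For the measured compounds named here, no measured pair here shows a change of this kind, so the expectation is loose: a modest move toward a higher number, meaning a weaker inhibitor, in this assay. The expected change is a 2.6-fold higher number from compound 2 to compound 4 (0.42 log units; beyond the scatter). For compound 4 the estimated value is 600 nM, with an expected range of 120 nM to 4000 nM.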

Compound 4, half-maximal inhibitory concentration: 3560 nM
Compound 4: the middle estimate sits 5.9-fold (0.77 log units) below what was measured; the range from low to high includes it.
By their numbers in this assay, from the lowest: compound 2; then compound 3; then compound 4. At a limit, above all of these: compound 1.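

In this assay, among the compounds shown here, this saturated chain carbon bound to a sulfonyl sulfur proves a sensitive place: going from methylsulfonyl to butylsulfonyl gives a 15-fold higher number from compound 2 to compound 4 (1.19 log units; beyond the scatter) and is the first measured change here. The two compounds differ in this one place, so the weakening goes with the added propyl. Compound 4 still gives an exact number, not a limit, so the full size of the step can be read: the limit of > 20000 nM in this assay, at which 1 of the 4 values shown sits.

Only methyl and butyl are shown here, so the course between them stays open. An ethyl or propyl chain, or a chain ending in an amine, could show whether the loss builds gradually.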